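The source may report more compounds than this note shows. Statements on the series, on what has been measured and on what is new or still open speak of the compounds shown alone.

Working notes on the series, all read in a functional assay on the whole organism (strain albino) with Mus musculus as the target, with a stated time of 0.5 h; on this read-out higher numbers stand for an effect only at larger amounts of compound and lower numbers for an effect already at smaller amounts. Among the measured compounds shown here, only one number is available so far. Compound 3 (`CC(=O)N1N=C(Nc2nc3ccc(C)cc3s2)CC1c1ccc(Cl)cc1`) gives 27.5 umol/kg, which leaves it with no measured neighbour to be ranked against. Compound 1 (`COc1ccc(C2CC(Nc3nc4ccc([N+](=O)[O-])cc4s3)=NN2C(C)=O)cc1O`) is entered as "not determined" (no result reported). Compound 2 (`CC(=O)N1N=C(Nc2nc3ccc([N+](=O)[O-])cc3s2)CC1c1ccc(O)cc1`) is likewise entered as "not determined" (no result reported). These two entries carry no information on potency, even though both compounds bear the nitro group that is of interest here.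

The next compound is compound 4 (`CC(=O)N1N=C(Nc2nc3ccc([N+](=O)[O-])cc3s2)CC1c1ccc(Cl)cc1`), which differs from compound 3 at a single place: nitro in place of methyl on an aromatic carbon, para to a fused ring and meta to a fused ring (nitro in place of methyl on an aromatic carbon). For the measured compounds named here, the series contains no measured pair that isolates this exchange, so neither the size nor the direction of the step can be read from the data. The expectation therefore rests on compound 3 at 27.5 umol/kg, with a wide margin on both sides. No shift beyond the usual scatter is expected, and the estimated change is a 1.1-fold lower number from compound 3 to compound 4 (0.02 log units; within the scatter). In this assay, the expected value for compound 4 is 26 umol/kg, within an estimated range of 10 umol/kg to 65 umol/kg.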

Compound 4, dose for half-maximal effect: 138 umol/kg
Compound 4: middle estimate off by 5.3-fold (0.72 log units), on the low side, outside the stated range (above it).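

Nitro in place of methyl on an aromatic carbon, para to a fused ring and meta to a fused ring, gives a 5.0-fold higher number from compound 3 to compound 4 (0.70 log units; beyond the scatter) in this assay, the first measured pair of the series. This position is therefore not indifferent to the exchange: with the rest of the structure unchanged, the nitro compound needs a larger amount of compound for its effect than the methyl compound. The data at hand give no reason for this step.

Among the compounds shown here, whether an amine or a carboxylic acid on the same aromatic carbon would read closer to methyl or to nitro remains open, so the single pair gives a direction for these two groups and no trend across substituents. Also open, on these data alone, is whether the same step holds when the chlorine of compound 3 and compound 4 gives way to the other substituents on that ring, since compound 1 and compound 2, both nitro compounds, carry no number on this read-out.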